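Phenyl to Indolyl: Projecting Compound 4 from Three Analogues

The source may hold more compounds than are shown below. What is called first, only, known or untested is meant among the compounds shown, and "the series" means these compounds.

Compound 1 `COc1cc(-c2cccc3nc(-c4ccccc4)oc23)cc(OC)c1OC` is the point of departure. In a functional assay on U-251 cells (Homo sapiens) for antiproliferative activity, read by MTT assay, with a stated time of 48 h (a lower number here means a stronger inhibitor, a higher number a weaker inhibitor), compound 1 gives 3500 nM, the highest number among the three measured compounds. Compound 2 `COc1cc(-c2cccc3nc(-c4cccc(F)c4)oc23)cc(OC)c1OC` gives 2900 nM in this assay, and compound 3 `COc1cc(-c2cccc3nc(-c4cccc(N)c4)oc23)cc(OC)c1OC` gives 2200 nM. The steps between them are all modest: a 1.2-fold lower number from compound 1 to compound 2 (0.08 log units; within the scatter), a 1.6-fold lower number from compound 1 to compound 3 (0.20 log units; within the scatter), and a 1.3-fold lower number from compound 2 to compound 3 (0.12 log units; within the scatter).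

Compound 4 `COc1cc(-c2cccc3nc(-c4ccc5cc[nH]c5c4)oc23)cc(OC)c1OC` differs from compound 1 by 1H-indol-6-yl in place of phenyl on an aromatic carbon. Among the compounds with values here, no measured step tests an exchange of the whole ring; the two available steps show only that placing fluoro or amino on that ring leaves the number within the scatter. With nothing beyond that to draw on, the expectation for compound 4 is a number close to that of compound 1, possibly somewhat lower, but not clearly outside the scatter. Compound 4 is therefore expected to move by a 1.6-fold lower number from compound 1 to compound 4 (0.20 log units; within the scatter). The estimate for compound 4 in this assay is 2200 nM, with a range from 700 nM to 7000 nM.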

Compound 4, half-maximal inhibitory concentration: 300 nM
The estimate for compound 4 lay 7.3-fold (0.87 log units) above the measured number; measured number below the stated range.
By their numbers in this assay, from the lowest: compound 4; then compounds 3, 2 and 1 (each within the scatter of the next).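

In this assay the exchange of phenyl for 1H-indol-6-yl gives a 12-fold lower number from compound 1 to compound 4 (1.07 log units; beyond the scatter) and so shows that the group on this aromatic carbon, next to the ring nitrogen and next to the ring oxygen, can move the number beyond the scatter, which fluoro and amino on the phenyl ring did not do. Compound 4 also stands apart from both substituted analogues, with a 9.7-fold lower number from compound 2 to compound 4 (0.99 log units; beyond the scatter) and a 7.3-fold lower number from compound 3 to compound 4 (0.87 log units; beyond the scatter) on the same exchange. Nothing available explains this step.

The compounds shown leave open whether the step needs the hydrogen on the indole nitrogen or only the second ring, a question that 1-methyl-1H-indol-6-yl and naphthalen-2-yl would separate. They also leave open whether the point of attachment matters, as 1H-indol-5-yl would show.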